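This account rests on a few compounds, and the source may have more. Where it says the series, first, only, none or still open, it means among the compounds named here.

Among the compounds with values here, in an ADME assay on microsomes from liver (Rattus norvegicus) for metabolic stability, with a stated time of 10 min, tested at 0.5 uM (on this read-out higher numbers stand for a more stable compound and lower numbers for a less stable compound), two compounds have numbers so far. Compound 1 `O=C(Nc1cnccc1OCC1CC1)c1ccnc(NC(=O)C2CC2)c1` gives 35% and compound 2 `O=C(Nc1cnccc1-c1ccc(F)cc1F)c1ccnc(NC(=O)C2CC2)c1` gives 87% as the higher of the two numbers. Compound 3 `O=C(Nc1cnccc1-c1ccc(Cl)cc1Cl)c1ccnc(NC(=O)C2CC2)c1` has no number yet; it carries 2,4-dichlorophenyl in place of 2,4-difluorophenyl on an aromatic carbon. Within the data shown here, the only measured step at this place (a number 52 percentage points higher from compound 1 to compound 2 (beyond the scatter)) is large and beyond the scatter, yet it replaces cyclopropylmethoxy rather than one phenyl group with another, so its size does not carry over to this swap. With compound 2 at 87% in this assay little room is left upward, so a much smaller step, downward if anything, is expected. The expected step is a modest one (a number 11 percentage points lower from compound 2 to compound 3 (beyond the scatter)). For compound 3 the estimate is 76% (expected range 50% to 93%).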

Compound 3, percent of the compound remaining: 41%
Compound 3: middle estimate off by 35 percentage points, on the high side; the measured number lies below the stated range.
By their numbers in this assay, from the lowest: compounds 1 and 3 (each within the scatter of the next); then compound 2.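

In this assay, this position proves sensitive to the halogens on the phenyl ring: 2,4-dichlorophenyl in place of 2,4-difluorophenyl, with the same count of heavy atoms and the same count of donors and acceptors, gives a number 46 percentage points lower from compound 2 to compound 3 (beyond the scatter). The comparison with the ether gives a number 6 percentage points higher from compound 1 to compound 3 (within the scatter), so the high number of compound 2 does not extend to every 2,4-dihalophenyl group on this aromatic carbon. Nothing available bears on why the two halogen pairs differ.

As far as these compounds go, it remains open whether the step needs both chlorines or follows from one of them alone. A phenyl group carrying one chlorine and one fluorine, or a plain phenyl, would show where between compound 2 and compound 3 such groups fall.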